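The source may hold more compounds than are shown below. What is called first, only, known or untested is meant among the compounds shown, and "the series" means these compounds.

Compound 1 `CCCC(=O)OCSc1ccccc1C(=O)NCCC(N)=O`: > 100 uM, a limit of the assay
Compound 2 `CCCC(=O)OCSc1ccccc1C(=O)NCC(N)=O`: > 100 uM, a limit of the assay
Compound 3 `CCCC(=O)OCSc1ccccc1C(=O)NCCCCC(N)=O`: 51.7 uM

Going by the values given here, in an ADME assay on CEM-SS cells (Homo sapiens) for cytotoxicity, read by XTT assay, with a stated time of 6 days (on this read-out higher numbers stand for lower toxicity in this test and lower numbers for higher toxicity in this test), compound 3 gives 51.7 uM, the only true number of the three. The other two values are limits.

Compound 4 `CCCC(=O)OCSc1ccccc1C(=O)NCCCCCCC(N)=O` differs from it in one place: 2-carbamoylethyl in place of carbamoyl on a saturated chain carbon, four bonds along the chain from an amide-type nitrogen.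

The closest guide is the same exchange made two bonds along the chain, which gave an at least 1.9-fold lower number from compound 1 to compound 3 (0.28 log units; that floor lies within the scatter). The longer extension gave an at least 1.9-fold lower number from compound 2 to compound 3 (0.28 log units; that floor lies within the scatter). Both floors lie within the scatter, so the direction is only weakly supported, while a step that the two limits leave unreadable from compound 1 to compound 2 tells nothing.

A modest move toward higher toxicity is therefore expected, with an estimated 1.8-fold lower number from compound 3 to compound 4 (0.27 log units; within the scatter).

For compound 4 the estimate is 28 uM, with an expected range of 11 uM to 70 uM.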

Compound 4, half-maximal toxic concentration: 10.4 uM
Estimate against measurement, compound 4: 2.7-fold (0.43 log units) above; measured number outside the range, below it.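

In this assay, going by these compounds alone, the longer chain gives a 5.0-fold lower number from compound 3 to compound 4 (0.70 log units; beyond the scatter), the first step with a readable size that lies beyond the scatter. Compound 4 also separates clearly from the two shorter-chain compounds, with an at least 9.6-fold lower number from compound 2 to compound 4 (0.98 log units; beyond the scatter) and an at least 9.6-fold lower number from compound 1 to compound 4 (0.98 log units; beyond the scatter). These two steps are only floors, because compound 1 and compound 2 each sit at a limit: the limit of > 100 uM in this assay, at which 2 of the 4 values shown sit.

On these data alone, whether a still longer chain would keep lowering the number remains open. So does the effect of a carboxylic acid or an amine in place of the carbamoyl.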